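This account rests on a few compounds, and the source may have more. Where it says the series, first, only, none or still open, it means among the compounds named here.

Notes on the amide series. Compound 3 `COc1ccccc1NC(=O)CC1CCc2cc(OC)c(OC)cc21` gives 24.5% in a functional assay on the whole organism (strain Swiss Albino) for inhibition, with Mus musculus as the target, in the writhing test, with a stated time of 1 h, at a dose of 100 mg/kg by the oral route (a lower number here means less inhibition, a higher number more inhibition at the dose given (going by the name of the read-out)), the lowest of the three measured numbers; compound 1 `COc1cc2c(cc1OC)C(CC(=O)Nc1ccccc1C)CC2` gives 30%, a value within the scatter of compound 3, and compound 2 `COc1cc2c(cc1OC)C(CC(=O)Nc1ccc(C)cc1)CC2` gives 41.4%. Compound 4 `COc1cc2c(cc1OC)C(CC(=O)Nc1ccccn1)CC2` is the next member, differing from compound 3 as follows: pyridin-2-yl in place of 2-methoxyphenyl on an amide-type nitrogen.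

Among the measured steps, only the swaps of the group on the amide nitrogen are comparable in kind. There, a number 11.4 percentage points higher from compound 1 to compound 2 (beyond the scatter) and a number 16.9 percentage points lower from compound 2 to compound 3 (beyond the scatter) show modest movements, while a number 5.5 percentage points lower from compound 1 to compound 3 (within the scatter) stays within the scatter. Going by the values given here, no measured step introduces pyridin-2-yl, so the direction for compound 4 cannot be read from any single step; the measured swaps on the amide nitrogen cover only a modest window of inhibition.

Compound 4 is therefore expected to land near the measured range, with a small upward step a number 5.5 percentage points higher from compound 3 to compound 4 (within the scatter) from compound 3 that may not exceed the scatter. The estimate for compound 4 is 30%, with a range from 15% to 45%.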

Compound 4, a percentage reported as inhibition, in the whole organism at one dose (the size of the read-out at that dose, not a potency): 48.1%
For compound 4 the middle estimate is 18.1 percentage points below the measured one, and the stated range ends below it.
By their numbers in this assay, from the lowest: compounds 3 and 1 (each within the scatter of the next); then compounds 2 and 4 (each within the scatter of the next).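

Pyridin-2-yl is the first ring with a hetero atom on the amide-type nitrogen in this series, and in this assay it gives a number 23.6 percentage points higher from compound 3 to compound 4 (beyond the scatter) and a number 18.1 percentage points higher from compound 1 to compound 4 (beyond the scatter) against the two groups that leave the lowest numbers. Against 4-methylphenyl the same swap gives a number 6.7 percentage points higher from compound 2 to compound 4 (within the scatter) so a ring of carbon only can keep pace with pyridin-2-yl at this position, and the presence of a ring hetero atom does not by itself separate the high pair from the low pair. Nothing measured here bears on the reason for these steps.

The compounds shown leave open how an unsubstituted phenyl group or a pyrimidinyl group would read at this nitrogen. They also leave open what a longer chain between the carbonyl and the shared core would do.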